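The source may hold more compounds than are shown below. What is called first, only, known or untested is meant among the compounds shown, and "the series" means these compounds.

Measured compounds in the series:

- compound 1, `O=C(CSc1nnc(-c2ccncc2)s1)NCc1ccccc1Cl`: "not determined" (no result reported)
- compound 2, `O=C(CSc1nnc(-c2ccncc2)s1)Nc1ccc(Cl)cc1Cl`: "not determined" (no result reported)
- compound 3, `O=C(CSc1nnc(-c2ccncc2)s1)Nc1ccccc1Cl`: > 50000 nM

In an ADME assay on BHK-21 cells (Mesocricetus auratus) for cytotoxicity, with a stated time of 3 days (a higher number here means that more compound is tolerated, a lower number that less compound is tolerated), only compound 3 carries an entry with a number attached, and that entry is a limit of the assay rather than a measured value: compound 3 gives > 50000 nM. For compound 1 and compound 2 no result is reported in this assay, so compound 3 cannot be placed relative to either of them; it stands alone, and what is known of it is summed up by the limit of > 50000 nM in this assay, at which 1 of the 3 values shown sits. Within the data shown here, no step between two measured compounds exists in this set.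

The next compound, compound 4, `O=C(CSc1nnc(-c2ccncc2)s1)NCc1ccccc1`, differs from compound 3 in one place: benzyl in place of 2-chlorophenyl on an amide-type nitrogen. Among the measured compounds shown here, with no measured step to lean on, the expectation rests on compound 3 alone, whose entry of > 50000 nM sits at the limit. The expected step from compound 3 to compound 4, a step that the limit leaves unreadable from compound 3 to compound 4, is therefore none beyond the scatter, with a good chance that compound 4 also returns only a limit. Compound 4 is estimated at 60000 nM, with a range from 30000 nM to 150000 nM.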

Compound 4, half-maximal cytotoxic concentration: 11300 nM
Beside the measured number, compound 4's estimate is 5.3-fold (0.73 log units) above it, outside the stated range (below it).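

In this assay, the group on the amide-type nitrogen now proves able to shift the read-out: benzyl in place of 2-chlorophenyl gives an at least 4.4-fold lower number from compound 3 to compound 4 (0.64 log units; beyond the scatter). Compound 4 also gives the series its first actual number in this read-out, a fixed point against which further changes at this nitrogen can be compared. From the compounds shown here alone, the size of the step can be read only from one side, and its true extent stays unknown, because one end of it is not a measured value: the limit of > 50000 nM in this assay, at which 1 of the 4 values shown sits.

The step takes away the chlorine and brings in the benzyl group in a single change, and the numbers shown do not separate the contribution of the ring chlorine from that of the extra carbon in the benzyl group. Going by these compounds, whether a longer chain on this nitrogen, such as phenethyl, or an amine on the aromatic ring would move the number in this assay further in either direction also remains open, as does whether this one step holds for other groups at the same place.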